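Fluoro for chloro on the aryl of compound 3

A few compounds are considered here, and "the series" means these few. Any claim that something is new, unique, unknown or untested is made for them only; others in the source may bear on it.

Three analogues share one core and differ only in the substituent on the phenyl ring. Compound 1 `Cc1nc(NC(C2CC2)C2CC2)c2nc(C)n(-c3ccc(C#N)cc3)c2n1` carries a nitrile and gives 62 nM in a functional assay on CHO cells for antagonist activity at corticotropin-releasing factor receptor 1 (Homo sapiens), read by cAMP accumulation; a higher number here means a weaker inhibitor, a lower number a stronger inhibitor. Compound 2 `Cc1nc(NC(C2CC2)C2CC2)c2nc(C)n(-c3ccc(S(C)(=O)=O)cc3)c2n1` carries a methylsulfonyl and gives 140 nM in this assay. Compound 3 `Cc1nc(NC(C2CC2)C2CC2)c2nc(C)n(-c3ccc(Cl)cc3)c2n1` carries a chloro and gives 11 nM in this assay, the lowest of the three numbers: the step of a 5.6-fold lower number from compound 1 to compound 3 (0.75 log units; beyond the scatter) is modest and beyond the scatter, while a 13-fold lower number from compound 2 to compound 3 (1.10 log units; beyond the scatter) is large. The remaining step, a 2.3-fold higher number from compound 1 to compound 2 (0.35 log units; beyond the scatter), runs the other way and is modest.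

Compound 4 `Cc1nc(NC(C2CC2)C2CC2)c2nc(C)n(-c3ccc(F)cc3)c2n1` is not yet measured. Its change from compound 3 is fluoro in place of chloro on an aromatic carbon. Among the compounds with values here, no measured step replaces chloro with fluoro, so the two steps that end at compound 3 are the only guide, and both show that the identity of this para group moves the number well beyond the scatter. Compound 4 is therefore expected to lie above compound 3, with the step of a 2.7-fold higher number from compound 3 to compound 4 (0.44 log units; beyond the scatter) estimated as modest rather than large. Compound 4 is estimated to give 30 nM in this assay, within a range of 12 nM to 80 nM.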

Compound 4, inhibition constant: 91 nM
Compound 4: middle estimate off by 3.0-fold (0.48 log units), on the low side, outside the stated range (above it).
By their numbers in this assay, from the lowest: compound 3; then compounds 1, 4 and 2 (each within the scatter of the next, the first and the last beyond it).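

Exchanging one halogen for another is not a minor change at this position: in this assay, the swap of chloro for fluoro gives an 8.3-fold higher number from compound 3 to compound 4 (0.92 log units; beyond the scatter), so the advantage of compound 3 does not extend to the 4-fluorophenyl analogue. Fluoro instead falls in with the two other groups, with a 1.5-fold lower number from compound 2 to compound 4 (0.19 log units; within the scatter) and a 1.5-fold higher number from compound 1 to compound 4 (0.17 log units; within the scatter), although the nitrile and methylsulfonyl analogues remain separated from each other beyond the scatter; among these four compounds, only compound 3 has steps to all the others printed as beyond the scatter, which makes it the strongest inhibitor of the set. Nothing available explains why chloro and fluoro part so widely here.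

The compounds shown leave open whether the low number belongs to chloro alone or would also be reached with bromo, methyl or methoxy on the same aromatic carbon. They also leave open whether the gap between chloro and fluoro would persist if the dicyclopropylmethyl group on the amine gave way to a longer chain, since all four compounds share that group.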